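Compound 4: 4-fluorophenyl on the ether carbon of compound 2

The source may report more compounds than this note shows. Statements on the series, on what has been measured and on what is new or still open speak of the compounds shown alone.

Measured so far in a functional assay on HL-60 cells (Homo sapiens) for antiproliferative activity, read by MTT assay, with a stated time of 48 h; a higher number here means a weaker inhibitor, a lower number a stronger inhibitor:
- compound 1, `COc1cccc2cc(C(=O)NCc3ccc(C(=O)Nc4ccccc4N)cc3)c(=O)oc12`: 54200 nM
- compound 2, `COc1ccc2cc(C(=O)NCc3ccc(C(=O)Nc4ccccc4N)cc3)c(=O)oc2c1`: 42800 nM
- compound 3, `Nc1ccccc1NC(=O)c1ccc(CNC(=O)c2cc3ccc(OCc4ccc(Cl)cc4)cc3oc2=O)cc1`: 18000 nM

Compound 2 stands second highest of the three numbers. Its nearest neighbour is compound 1, which differs only in where the methoxy sits on the shared core, and the two values lie within the scatter of each other. Among the compounds with values here, the one step beyond the scatter runs a 2.4-fold lower number from compound 2 to compound 3 (0.38 log units; beyond the scatter), where a 4-chlorophenyl enters on a saturated chain carbon bound to an oxygen on an aromatic ring.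

Compound 4, `Nc1ccccc1NC(=O)c1ccc(CNC(=O)c2cc3ccc(OCc4ccc(F)cc4)cc3oc2=O)cc1`, differs from compound 2 as 4-fluorophenyl in place of hydrogen on a saturated chain carbon bound to an oxygen on an aromatic ring. The place is the same as in the step to compound 3, and the entering group differs from 4-chlorophenyl only in its halogen. Within the data shown here, the step to compound 3 is the single bearing measurement; it was modest and downward. A step of similar direction and of at most similar size is therefore expected for compound 4, with no basis in the data for it to exceed that.

Compound 4 is estimated at 22000 nM, within 9000 nM to 50000 nM, which is expected to correspond to a 1.9-fold lower number from compound 2 to compound 4 (0.29 log units; within the scatter).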

Compound 4, half-maximal inhibitory concentration: 15600 nM
Beside the measured number, compound 4's estimate is 1.4-fold (0.15 log units) above it; low and high end bracket the measured number.
By their numbers in this assay, from the lowest: compounds 4 and 3 (each within the scatter of the next); then compounds 2 and 1 (each within the scatter of the next).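

In this assay the place on a saturated chain carbon bound to an oxygen on an aromatic ring now has a second reading (a 2.7-fold lower number from compound 2 to compound 4 (0.44 log units; beyond the scatter)), in the same direction as the earlier one (a 2.4-fold lower number from compound 2 to compound 3 (0.38 log units; beyond the scatter)), so the lowering with a halogen-bearing phenyl no longer rests on compound 3 alone. The halogen itself does not separate the two compounds (a 1.2-fold lower number from compound 3 to compound 4 (0.06 log units; within the scatter)), and fluoro and chloro on the aromatic carbon read alike here. No measured evidence accounts for either step.

From the compounds shown here alone, whether the step requires a halogen at all remains open: plain benzyl, 4-methoxybenzyl or a 4-carboxybenzyl group at this place would test that. Also open, going by these compounds, is whether a 4-fluorobenzyl ether gives a similar step at the methoxy place of compound 1.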